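The compounds below may be only part of what the source reports. "The series", "measured", "known", "first", "only" and "open" are said of these compounds alone.

Working notes on the series.

Compound 1 `C=C1[C@@H](OC(C)=O)C[C@@H]2[C@](C)(CO[Si](C)(C)C(C)(C)C)[C@H](OC(C)=O)CC[C@@]2(C)[C@@H]1C[C@@H](Nc1ccccc1)C1=CCOC1=O` gives 5710 nM in a functional assay on KB cells (Homo sapiens) for cytotoxicity, read by sulforhodamine B assay; a higher number here means a weaker inhibitor, a lower number a stronger inhibitor. Of the three numbers in hand it is the second highest. Compound 3 `C=C1CC[C@@H]2[C@](C)(CO[Si](C)(C)C(C)(C)C)[C@H](OC(C)=O)CC[C@@]2(C)[C@@H]1C/C=C1/C(=O)OC[C@H]1OC(C)=O` gives 5050 nM in this assay, a number that sits within the scatter of compound 1, so no order between the two can be read. Among the measured compounds shown here, compound 2 `C=C1[C@@H](OC(C)=O)C[C@@H]2[C@](C)(COC=O)[C@H](OC(C)=O)CC[C@@]2(C)[C@@H]1C[C@@H](Nc1ccccc1C(=O)O)C1=CCOC1=O` gives 42500 nM in this assay, a higher number than compound 1 and beyond the scatter; compound 2 differs from compound 1 in more than one place, so its two values show only that the pair is apart, not which change carries it.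

Compound 4 `C=C1[C@@H](OC(C)=O)C[C@@H]2[C@](C)(CO[Si](C)(C)C(C)(C)C)[C@H](OC(C)=O)CC[C@@]2(C)[C@@H]1C[C@@H](Nc1ccc(OC)c(OC)c1)C1=CCOC1=O` is the next compound to be measured in this assay. Its change from compound 1 is 3,4-dimethoxyphenyl in place of phenyl on an amine nitrogen. For the measured compounds named here, no measured pair differs by this change alone, so there is no step to lean on. The core and the rest of the molecule are unchanged, and the change sits at the edge of the structure. The expectation is for compound 4 a step from compound 1 of a 1.1-fold higher number from compound 1 to compound 4 (0.02 log units; within the scatter), that is, no step beyond the scatter in either direction. Compound 4 is estimated at 6000 nM, with a range from 2500 nM to 15000 nM.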

Compound 4, half-maximal inhibitory concentration: 5800 nM
Estimate against measurement, compound 4: 1.0-fold (0.01 log units) above, within the range that was stated.
By their numbers in this assay, from the lowest: compounds 3, 1 and 4 (each within the scatter of the next); then compound 2.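

Among the compounds shown here, the step of a 1.0-fold higher number from compound 1 to compound 4 (0.01 log units; within the scatter) in this assay is the first that isolates a single change, 3,4-dimethoxyphenyl in place of phenyl on an amine nitrogen. Compound 2 could not show this, since it differs from compound 1 in more than one place. Here the entering group is larger than phenyl and carries hydrogen-bond acceptors that phenyl lacks, yet the two compounds cannot be told apart in this read-out, so at this position neither the added size nor those acceptors come with a difference beyond the scatter. No measurement in hand bears on why this change leaves the number within the scatter.

Open, on these data alone, is how a pyridine ring, or a plain alkyl chain in place of the aryl ring on this nitrogen, would read in this assay. Also open, as far as these compounds go, is whether a carboxylic acid on the aryl ring, taken alone with the rest of compound 1 unchanged, would move the number, since this single step speaks only for 3,4-dimethoxyphenyl.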